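Replacing the 4-acetylphenyl group of compound 2

The compounds below may be only part of what the source reports. "The series", "measured", "known", "first", "only" and "open" are said of these compounds alone.

- compound 1 `CC(Nc1ccccc1Oc1cccc(F)c1)=C1C(=O)CC(c2ccccc2)CC1=O` gives 550 nM
- compound 2 `CC(=O)c1ccc(Oc2ccccc2NC(C)=C2C(=O)CC(c3ccccc3)CC2=O)cc1` gives 130 nM
- compound 3 `COc1ccc(Oc2ccccc2NC(C)=C2C(=O)CC(c3ccccc3)CC2=O)cc1` gives 160 nM

All three numbers come from a functional assay on HeLa cells (Homo sapiens) for antiproliferative activity, read by cell counting, with a stated time of 3 days (on this read-out lower numbers stand for stronger inhibition and higher numbers for weaker inhibition), and can be compared directly. Compound 2 shares the low end of these numbers with compound 3, the two lying within the scatter of each other, while compound 1 stands clearly higher.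

The next compound, compound 4 `COc1cc(Oc2ccccc2NC(C)=C2C(=O)CC(c3ccccc3)CC2=O)ccc1N`, carries 4-amino-3-methoxyphenyl in place of 4-acetylphenyl on an oxygen on an aromatic ring. Among the compounds with values here, three measured steps bear on this place. Leaving 3-fluorophenyl gave modest drops (a 4.2-fold lower number from compound 1 to compound 2 (0.63 log units; beyond the scatter)) and (a 3.4-fold lower number from compound 1 to compound 3 (0.54 log units; beyond the scatter)), whereas methoxy in place of acetyl moved the number no further than the scatter (a 1.2-fold higher number from compound 2 to compound 3 (0.09 log units; within the scatter)). Within the data shown here, no measured compound carries an amino group, so this expectation remains uncertain. In this assay no step beyond the scatter is expected, in either direction (a 1.2-fold higher number from compound 2 to compound 4 (0.09 log units; within the scatter)). Compound 4 is expected at 160 nM (estimated range 55 nM to 480 nM).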

Compound 4, half-maximal inhibitory concentration: 33 nM
Estimate against measurement, compound 4: 4.8-fold (0.69 log units) above; the whole stated range lies above it.
By their numbers in this assay, from the lowest: compound 4; then compounds 2 and 3 (each within the scatter of the next); then compound 1.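

In this assay, within the data shown here, the place on an oxygen on an aromatic ring turns out to hold more range than the earlier compounds showed: 4-amino-3-methoxyphenyl in place of 4-acetylphenyl gives a clear gain (a 3.9-fold lower number from compound 2 to compound 4 (0.60 log units; beyond the scatter)). Acetyl and methoxy had stayed within the scatter of each other, yet the new group also stands apart from 4-methoxyphenyl (a 4.8-fold lower number from compound 3 to compound 4 (0.69 log units; beyond the scatter)), so adding the amino group and moving a methoxy group together changed what a single swap of acetyl for methoxy had not. Measured from 3-fluorophenyl, the step becomes the only large one in this set (a 17-fold lower number from compound 1 to compound 4 (1.22 log units; beyond the scatter)).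

Nothing available accounts for this gain. As far as these compounds go, whether it follows the amino group alone, and whether 4-aminophenyl or 4-hydroxyphenyl would do the same, stays open.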